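Indol-6-yl for hydroxy-methoxyphenyl: notes on compound 4

This account rests on a few compounds, and the source may have more. Where it says the series, first, only, none or still open, it means among the compounds named here.

Compound 2 `COc1ccc(-c2cncnc2-c2cc(OC)c(OC)c(OC)c2)cc1O` gives 2750 nM in a functional assay on SiHa cells (Homo sapiens) for antiproliferative activity, read by CCK-8 assay, with a stated time of 72 h; on this read-out higher numbers stand for weaker inhibition and lower numbers for stronger inhibition. Within this set it carries the lowest number, yet compound 1 `COc1ccc(-c2cncnc2-c2cc(OC)c(OC)c(OC)c2)cc1` with 2850 nM sits with it inside the scatter, while compound 3 `CCOc1ccc(-c2cncnc2-c2cc(OC)c(OC)c(OC)c2)cc1C(F)(F)F` with 20000 nM lies well beyond. Within the data shown here, the only single step known, a 1.0-fold lower number from compound 1 to compound 2 (0.02 log units; within the scatter), shows that a hydroxy added to the shared core's aryl group changes nothing beyond the scatter. Compound 4 `COc1cc(-c2ncncc2-c2ccc3cc[nH]c3c2)cc(OC)c1OC` differs from compound 2 by 1H-indol-6-yl in place of 3-hydroxy-4-methoxyphenyl on an aromatic carbon. Among the measured compounds shown here, no measured step exchanges this aryl group for a fused ring, so nothing here argues for a shift in either direction; the expectation is a step of a 1.1-fold lower number from compound 2 to compound 4 (0.04 log units; within the scatter), within the scatter. Compound 4 is therefore estimated at 2500 nM, with a range of 700 nM to 9000 nM.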

Compound 4, half-maximal inhibitory concentration: 2180 nM
The estimate for compound 4 lay 1.1-fold (0.06 log units) above the measured number, within the range that was stated.
By their numbers in this assay, from the lowest: compounds 4, 2 and 1 (each within the scatter of the next); then compound 3.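

Exchanging the whole aryl group, rather than adding a hydroxy to it, still gives only a step within the scatter, both as a 1.3-fold lower number from compound 2 to compound 4 (0.10 log units; within the scatter) and as a 1.3-fold lower number from compound 1 to compound 4 (0.12 log units; within the scatter). At this aromatic carbon, two atoms from the ring nitrogen, 1H-indol-6-yl therefore reads alike with 3-hydroxy-4-methoxyphenyl and 4-methoxyphenyl. No measured property is available to account for this.

Open, from the compounds shown here alone, is whether an aminomethyl or a carboxylic acid at this position would give a step beyond the scatter. Also open, going by these compounds, is how a methyl on the indole nitrogen would read.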